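Vero cytotoxicity notes: from compound 2 to compound 3

This account rests on a few compounds, and the source may have more. Where it says the series, first, only, none or still open, it means among the compounds named here.

Compound 2 `O=c1nc(N2CCN(NCc3ccc(Br)cc3)CC2)sc2c([N+](=O)[O-])cc(C(F)(F)F)cc12` has been tested in an ADME assay on Vero cells (Chlorocebus sabaeus) for cytotoxicity, read by MTT assay, with a stated time of 72 h; a lower number here means that less compound is tolerated, a higher number that more compound is tolerated. In this assay compound 2 gives > 64 ug/mL, which is a limit of the assay and not a number. Its closest neighbour, compound 1 `O=c1nc(N2CCN(NCCC3CCCCC3)CC2)sc2c([N+](=O)[O-])cc(C(F)(F)F)cc12`, differs only at a saturated chain carbon bound to an amine nitrogen, where cyclohexylmethyl stands in place of the 4-bromophenyl of compound 2. In this assay compound 1 gives > 64 ug/mL, again a limit. The step that the two limits leave unreadable from compound 1 to compound 2 is therefore unreadable, and the two results share (the limit of > 64 ug/mL in this assay, at which 2 of the 2 values shown sit).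

The next compound, compound 3 `O=c1nc(N2CCN(Nc3ccc(C(F)(F)F)cc3)CC2)sc2c([N+](=O)[O-])cc(C(F)(F)F)cc12`, awaits measurement. Its change from compound 2 is 4-(trifluoromethyl)phenyl in place of 4-bromobenzyl on an amine nitrogen. For the measured compounds named here, the only measured step, a step that the two limits leave unreadable from compound 1 to compound 2, touches the same part of the molecule but gives no size and no direction, and both known values rest at the limit, so nothing points toward lower tolerance. For compound 3 the step of a number no higher from compound 2 to compound 3 (the limit leaves the size open) is expected to stay within the scatter. The estimate for compound 3 in this assay is 64 ug/mL, with a range from 40 ug/mL to 100 ug/mL, most likely reported again as a limit.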

Compound 3, half-maximal cytotoxic concentration: > 64 ug/mL
Compound 3 was reported as a limit; the forecaster's own chance of this, stated with the estimate: 75%; the middle value sits exactly at the limit.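

In this assay the steps from compound 1 to compound 3 and from compound 2 to compound 3 cannot be read, so compound 3 adds no new step to the series: the limit of > 64 ug/mL in this assay, at which 3 of the 3 values shown sit.

The compounds shown leave open where the actual tolerated concentration of each lies, and whether the groups on the amine nitrogen differ at all in this read-out.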